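The source may hold more compounds than are shown below. What is called first, only, known or untested is meant among the compounds shown, and "the series" means these compounds.

Working notes on the series. Of the compounds shown here, three have so far been measured in an ADME assay on HeLa cells (Homo sapiens) for cytotoxicity, read by MTT assay, with a stated time of 48 h, tested at 25 uM; a lower number here means a stronger effect, a higher number a weaker effect of the compound at the concentration tested. Compound 1 `COc1cc2c(cc1OC)CN(CCCCn1nc(-c3ccccc3)oc1=O)CC2` gives 82%. Compound 2 `Cc1ccc(CN(C)CCCCn2nc(-c3ccccc3)oc2=O)c(C)c1` gives 74%. Compound 3 `O=C1CCc2ccccc2N1CCCCN1CCN(C2CCCCC2)CC1` gives 75%. On these three numbers compound 3 stands second highest; its nearest neighbour is compound 2, whose number lies within the scatter of it, and the number furthest from it, that of compound 1, also lies within the scatter. For the measured compounds named here, the three values therefore cannot be told apart, and no pair of measured compounds that differ in a single place is available to give a step.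

Compound 4 `O=C1CCc2ccccc2N1CCCCN1CCN(c2ccc(F)cc2)CC1` is not yet measured. It differs from compound 3 in one place:

4-fluorophenyl in place of cyclohexyl on an amine nitrogen in a ring

Going by the values given here, no measured pair in the set shows what this exchange does, so the expectation rests only on the level of the set and on compound 3 with its value of 75%. With all three measured numbers within the scatter of one another, the step in this assay is expected to be none beyond the scatter, a number 2 percentage points lower from compound 3 to compound 4 (within the scatter). Compound 4 is accordingly estimated at about 73% in this assay, with a range from 56% to 88%.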

Compound 4, a percentage reported as activity, at one concentration (the size of the read-out at that concentration, not a potency): 78%
Beside the measured number, compound 4's estimate is 5 percentage points below it; the range from low to high includes it.
By their numbers in this assay, from the lowest: compounds 2, 3, 4 and 1 (each within the scatter of the next).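

For the compounds shown here, this is the first pair that differs in one place, and in this assay it gives a first step (a number 3 percentage points higher from compound 3 to compound 4 (within the scatter)). On an amine nitrogen in a ring, an aromatic ring bearing fluorine and a non-aromatic ring of carbon only are therefore not told apart by this read-out at the single concentration tested, so the exchange of cyclohexyl for 4-fluorophenyl has no effect here that stands out from the scatter. No accompanying measurement bears on this result, and it comes with no explanation.

From the compounds shown here alone, it remains open whether other groups on the same nitrogen, such as an unsubstituted phenyl, a benzyl or a carboxylic acid on the ring, would also stay within the scatter of compound 3, since a single exchange cannot show how far this position tolerates change. Also open, going by these compounds, is whether 4-fluorophenyl in place of cyclohexyl would behave the same way on a different core, such as the core of compound 1, or with a longer chain in place of the present one.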